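Swapping the aryl group on a piperidine sulfonamide

A few compounds are considered here, and "the series" means these few. Any claim that something is new, unique, unknown or untested is made for them only; others in the source may bear on it.

Measured so far:
Compound 1 `Cc1cccc(S(=O)(=O)N2CCC(N3CCC(C)CC3)CC2)c1`; in an ADME assay on HCT-116 cells (Homo sapiens) for cytotoxicity, read by CellTiter-Glo, with a stated time of 72 h (a higher number here means a weaker inhibitor, a lower number a stronger inhibitor), compound 1 gives > 5000 nM.
Compound 2 `COc1cccc(S(=O)(=O)N2CCC(N3CCC(C)CC3)CC2)c1`; in this assay compound 2 gives > 5000 nM.

For compound 1 the value is a limit of the assay, not a number. For compound 2 the value is likewise a limit. The step that the two limits leave unreadable from compound 1 to compound 2 therefore cannot be read, because of the limit of > 5000 nM in this assay, at which 2 of the 2 values shown sit. Compound 2 stands at that limit.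

Compound 3 `CC1CCN(C2CCN(S(=O)(=O)c3cncc(Br)c3)CC2)CC1` differs from compound 2 by 5-bromopyridin-3-yl in place of 3-methoxyphenyl on a sulfonyl sulfur. Within the data shown here, no measured step bears on this change. Compound 3 is expected to give about 10000 nM, within 4000 nM to 30000 nM, a step that the limit leaves unreadable from compound 2 to compound 3 that is expected to stay within the scatter.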

Compound 3, half-maximal inhibitory concentration: > 10000 nM
Compound 3 was reported as a limit; the forecaster's own chance of this, stated with the estimate: 80%; the middle value lies on the limit itself.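

In this assay, among these compounds, compound 3 gives > 10000 nM, which is a limit, so no step linking it to compound 1 or compound 2 can be read. Whether changing the group on the sulfonyl sulfur alters the cytotoxicity of these compounds stays open.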